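The compounds below may be only part of what the source reports. "The series", "measured", "known", "first", "only" and "open" are said of these compounds alone.

Measured in an assay on microsomes from brain for inhibition of Fatty-acid amide hydrolase 1 (Rattus norvegicus), read by fluorescence and HPLC, with a stated time of 60 min; a lower number here means a stronger inhibitor, a higher number a weaker inhibitor:
compound 1 `CCCCCCCCc1ccc(OCC(=O)Cn2nnc(C)n2)cc1`, 27 nM
compound 2 `CCCCCCCCc1ccc(OCC(=O)Cn2nnc(-c3cccnc3)n2)cc1`, 23 nM
compound 3 `CCCCCCCCc1ccc(OCC(=O)Cn2nnnc2-c2ccc(Cl)cc2)cc1`, 130 nM

Compound 3 gives the highest of these three numbers; compound 1 lies nearest and compound 2 furthest, both beyond the scatter. Compound 4 `CCCCCCCCc1ccc(OCC(=O)Cn2nnnc2-c2cccs2)cc1` differs from compound 3 by thiophen-2-yl in place of 4-chlorophenyl on an aromatic carbon. Among the compounds with values here, the only measured change of a group on an aromatic carbon of the core is a 1.2-fold lower number from compound 1 to compound 2 (0.07 log units; within the scatter), and it sits on the core shared by compounds 1 and 2, which is not the core of compound 3. Within the data shown here, no measured step exchanges one aromatic ring for another, so there is no direct guide. A step in this assay that stays within the scatter is therefore expected, a 1.2-fold lower number from compound 3 to compound 4 (0.07 log units; within the scatter). For compound 4 the estimate is 110 nM, with a range of 40 nM to 350 nM.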

Compound 4, half-maximal inhibitory concentration: 55 nM
Compound 4: middle estimate off by 2.0-fold (0.30 log units), on the high side; low and high end bracket the measured number.
By their numbers in this assay, from the lowest: compounds 2 and 1 (each within the scatter of the next); then compound 4; then compound 3.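

At the aromatic carbon between two ring nitrogen atoms on the core of compound 3, thiophen-2-yl in place of 4-chlorophenyl gives a 2.4-fold lower number from compound 3 to compound 4 (0.37 log units; beyond the scatter) in this assay and is a modest change. Within the data shown here, this is the first step beyond the scatter for a group exchange on an aromatic carbon, since the earlier 1.2-fold lower number from compound 1 to compound 2 (0.07 log units; within the scatter) stayed within it on another core. No evidence at hand bears on what lies behind the step. Still open, on these data alone, is whether the step follows the loss of the chlorine or the change of ring, which plain phenyl at this position would separate.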